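The source may report more compounds than this note shows. Statements on the series, on what has been measured and on what is new or still open speak of the compounds shown alone.

Measured compounds:
Compound 1, `O=C1Nc2ccc(Cl)cc2/C1=N/NC(=S)N1CCN(c2ccccc2Cl)CC1`: 11700 nM
Compound 2, `O=C1Nc2ccc(Cl)cc2/C1=N/NC(=S)N1CCN(c2ccc(Cl)c(Cl)c2)CC1`: 10800 nM

Among the compounds with values here, in a functional assay on MCF7 cells (Homo sapiens) for inhibition, read by MTT assay, with a stated time of 72 h (on this read-out higher numbers stand for weaker inhibition and lower numbers for stronger inhibition), compound 2 gives 10800 nM, and the only other measured compound, compound 1, gives 11700 nM. The two lie close together: the step of a 1.1-fold lower number from compound 1 to compound 2 (0.03 log units; within the scatter) is within the scatter, so neither can be called the more potent of the pair.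

Compound 3, `O=C1Nc2ccc(Cl)cc2/C1=N/NC(=S)N1CCN(c2ccccc2[N+](=O)[O-])CC1`, differs from compound 2 in one place: 2-nitrophenyl in place of 3,4-dichlorophenyl on an amine nitrogen in a ring. Within the data shown here, the one measured step that bears on this change, a 1.1-fold lower number from compound 1 to compound 2 (0.03 log units; within the scatter), also swapped the aryl group on that same ring nitrogen and produced no movement beyond the scatter. Among the measured compounds shown here, with only that single step as guidance, no change beyond the scatter is expected in this assay either.

Compound 3 is therefore estimated at 11000 nM, with a likely range from 5000 nM to 25000 nM. This estimate amounts to an expected step of a 1.0-fold higher number from compound 2 to compound 3 (0.01 log units; within the scatter).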

Compound 3, half-maximal inhibitory concentration: 7490 nM
The estimate for compound 3 lay 1.5-fold (0.17 log units) above the measured number; measured number inside the range.
By their numbers in this assay, from the lowest: compounds 3, 2 and 1 (each within the scatter of the next).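

On the amine nitrogen in the ring, a nitro-bearing aryl group now stands alongside the two chlorinated ones. In this assay, swapping 3,4-dichlorophenyl for 2-nitrophenyl gives a step within the scatter (a 1.4-fold lower number from compound 2 to compound 3 (0.16 log units; within the scatter)), and nitro in place of chloro on an aromatic carbon does the same (a 1.6-fold lower number from compound 1 to compound 3 (0.19 log units; within the scatter)), so at this position a group with hydrogen-bond acceptors, which the chlorinated rings lack, sits level with them. Nothing available here offers a reason for these values.

Every aryl group shown carries chloro or nitro, so it remains open whether an unsubstituted phenyl, or a ring bearing a methoxy group, an amine or a carboxylic acid, would stay in the same range. Also open, as far as these compounds go, is whether a plain alkyl chain on that nitrogen, in place of the aromatic ring, would move the number beyond the scatter.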